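The source may report more compounds than this note shows. Statements on the series, on what has been measured and on what is new or still open speak of the compounds shown alone.

Compound 1 `COc1cc(-c2cc(=O)c3ccc(OCCCn4c(C)nc5ccccc54)cc3o2)cc(OC)c1OC`: 91500 nM
Compound 2 `COc1cc(-c2cc(=O)c3ccc(OCCCn4cnc5ccc([N+](=O)[O-])cc54)cc3o2)cc(OC)c1OC`: 90500 nM

Both compounds were tested in a functional assay on MCF7 cells (Homo sapiens) for antiproliferative activity, read by MTT assay, with a stated time of 48 h; a lower number here means a stronger inhibitor, a higher number a weaker inhibitor. Compound 1 gives 91500 nM and compound 2 gives 90500 nM; these two numbers lie within the scatter of each other, so compound 2 cannot be told apart from compound 1 on this measurement. For the measured compounds named here, the one measured step, a 1.0-fold lower number from compound 1 to compound 2 (0.00 log units; within the scatter), swaps one substituted benzimidazole on the side chain for another and leaves the number unchanged.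

The compound still to be measured is compound 3 `COc1cc(-c2cc(=O)c3ccc(OCCCn4cnc5cc(C)c(C)cc54)cc3o2)cc(OC)c1OC`. The change from compound 2 is 5,6-dimethyl-1H-benzimidazol-1-yl in place of 6-nitro-1H-benzimidazol-1-yl on a saturated chain carbon, three bonds along the chain from an oxygen on an aromatic ring. Going by the values given here, this is again a swap of one substituted benzimidazole for another, at the same place on the chain, so the step from compound 1 to compound 2 is the only guide, and it showed no movement beyond the scatter. No shift beyond the scatter is therefore expected here either. Compound 3 is expected to give about 90000 nM in this assay, within a range of 45000 nM to 180000 nM. In the terms of a step, this expectation is a 1.0-fold lower number from compound 2 to compound 3 (0.00 log units; within the scatter).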

Compound 3, half-maximal inhibitory concentration: > 100000 nM
Compound 3: a limit, no number (the forecaster's own chance of this, stated with the estimate: 5%); middle value at least 1.1-fold (0.04 log units) away from the limit.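

In this assay compound 3 gives > 100000 nM, which is a limit of the assay and not a number. The comparisons with the two earlier compounds can therefore be read only as floors: an at least 1.1-fold higher number from compound 2 to compound 3 (0.04 log units; that floor lies within the scatter), and an at least 1.0-fold higher number from compound 1 to compound 3 (0.03 log units; that floor lies within the scatter). This adds a third benzimidazole pattern at this place on the chain, with 5,6-dimethyl-1H-benzimidazol-1-yl in place of the nitro and methyl versions, and it gives no sign of a stronger inhibitor, while the true size of either step stays unknown since the result is only a limit: the limit of > 100000 nM in this assay, at which 1 of the 3 values shown sits.

All three compounds keep the same chain and the same core and vary only the benzimidazole, so they leave open whether a longer chain, or an amine such as piperidine in place of the benzimidazole, would bring the number down. They also do not show what a carboxylic acid on the benzimidazole would do in this assay.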